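The compounds below may be only part of what the source reports. "The series", "measured", "known", "first", "only" and "open" are said of these compounds alone.

In a physicochemical assay for solubility, read by HPLC, in phosphate buffer, with a stated time of 20 h, at pH 7.4 (a higher number here means a more soluble compound, a lower number a less soluble compound), compound 1 (`O=C(Nc1nnc(Cc2ccccc2)s1)c1ccc(O[C@H]2CC[C@@H](C(=O)O)CC2)nc1`) gives 89000 nM and compound 2 (`O=C(Nc1nc(Cc2ccccc2)no1)c1ccc(O[C@H]2CC[C@@H](C(=O)O)CC2)cc1`) gives 274000 nM as the higher of the two numbers, a gap beyond the scatter. For the measured compounds named here, no measured pair differs in one place only, so no step is at hand to scale the next change. Compound 3 (`O=C(Nc1nc(Cc2cc(F)cc(F)c2)no1)c1ccc(O[C@H]2CC[C@@H](C(=O)O)CC2)cc1`) carries 3,5-difluorophenyl in place of phenyl on a saturated chain carbon bound to an aromatic carbon and is otherwise the same as compound 2. With only the structural change to go on, a modest fall in this assay is expected, of a size that may stay close to the scatter. The expected move is a 1.7-fold lower number from compound 2 to compound 3 (0.23 log units; within the scatter) on this estimate. For compound 3 the estimated value is 160000 nM with a range of 60000 nM to 350000 nM in the same read-out.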

Compound 3, solubility: 813000 nM
Estimate against measurement, compound 3: 5.1-fold (0.71 log units) below, and the stated range ends below it.
By their numbers in this assay, from the lowest: compound 1; then compound 2; then compound 3.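

In this assay, for the compounds shown here, this is the first step that can be read at a single place: 3,5-difluorophenyl in place of phenyl on a saturated chain carbon bound to an aromatic carbon gives a 3.0-fold higher number from compound 2 to compound 3 (0.47 log units; beyond the scatter). The position is therefore not silent in this read-out, since a change that adds two fluorine atoms, with no hydrogen-bond donor, hydrogen-bond acceptor or net charge entering, moves the number beyond the scatter. No supporting measurement bears on the origin of this step.

One step on one core leaves open whether the same change would carry over to the core of compound 1. From the compounds shown here alone, it is also open whether chlorine atoms or methoxy groups in place of the fluorine atoms would move the number the same way.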